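The compounds below may be only part of what the source reports. "The series", "measured", "known", "first", "only" and "open" are said of these compounds alone.

Measured so far: compound 1 `Oc1nc(S)nc2ccc(Sc3ccc4ccccc4c3)cc12` gives 5 in an assay for inhibition of Dihydrofolate reductase (Homo sapiens); a higher number here means a more potent compound, by a factor of ten per unit of this negative logarithm, a lower number a less potent compound; compound 2 `Nc1nc(N)c2c(Cl)c(NC(=O)CCc3ccc(Cl)cc3)ccc2n1` gives 7.44; compound 3 `Nc1ncnc2ccc(Sc3ccc4ccccc4c3)cc12` gives 4.68.

Compound 3 stands lowest of these three numbers. Compound 1 lies above it by a margin beyond the usual scatter, and compound 2 lies far above it, well beyond the scatter.

Compound 4 `Nc1nc(S)nc2ccc(Sc3ccc4ccccc4c3)cc12` is the untested neighbour of compound 3. The change is sulfanyl in place of hydrogen on an aromatic carbon, the sulfur entering on the carbon between two ring nitrogen atoms of the fused system. Within the data shown here, no directly comparable pair has been measured. Compound 1, which also carries the sulfanyl, reaches 5 in this assay. A small upward step, about the size of the scatter, is expected: a number 0.32 log units higher from compound 3 to compound 4 (beyond the scatter). Compound 4 is therefore estimated at 5, within 4.4 to 5.7.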

Compound 4, logarithm of the reciprocal of the active concentration, log(1/C): 5.52
Compound 4: the middle estimate sits 0.52 log units below what was measured, and the stated range covers the measured number.
By their numbers in this assay, from the lowest: compound 3; then compound 1; then compound 4; then compound 2.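

Among these compounds, with the amino group kept, sulfanyl in place of hydrogen on the aromatic carbon between two ring nitrogen atoms gives a number 0.84 log units higher from compound 3 to compound 4 (beyond the scatter) and is the first step read at this position. With the sulfanyl kept, amino in place of hydroxy on an aromatic carbon gives a number 0.52 log units higher from compound 1 to compound 4 (beyond the scatter) and shows that the other substituent on this ring also matters. Nothing available explains either step.

Going by these compounds, whether an amine or a methyl group at the same carbon would match the sulfanyl remains open. So does whether both steps would hold if a longer chain replaced the side group on the shared core.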